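The compounds below may be only part of what the source reports. "The series", "measured", "known", "first", "only" and "open" are said of these compounds alone.

Compound 1 `O=C1COCC(=O)N1CCCCN1CCN(c2ncccc2-c2ccccc2)CC1` — 16 nM
Compound 2 `O=C1SC2(CCCC2)C(=O)N1CCCCN1CCN(c2ncccc2[N+](=O)[O-])CC1` — 34.1 nM
Compound 3 `O=C1COCC(=O)N1CCCCN1CCN(c2ncccc2Cl)CC1` — 16 nM

Three compounds were measured in an assay on isolated protein for binding affinity to Adrenergic receptor alpha-1 (Rattus norvegicus); a lower number here means a stronger inhibitor, a higher number a weaker inhibitor. Compound 1 `O=C1COCC(=O)N1CCCCN1CCN(c2ncccc2-c2ccccc2)CC1` gives 16 nM, and compound 3 `O=C1COCC(=O)N1CCCCN1CCN(c2ncccc2Cl)CC1` gives 16 nM; the step from one to the other, no change at the digits printed from compound 1 to compound 3 (within the scatter), shows that swapping the group on the pyridine ring left the number where it was. Compound 2 `O=C1SC2(CCCC2)C(=O)N1CCCCN1CCN(c2ncccc2[N+](=O)[O-])CC1`, which carries a different core and a nitro group on the pyridine, gives 34.1 nM and stands at the highest of the three numbers, with compound 1 and compound 3 both at lower numbers.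

Compound 4 `O=C1SC2(CCCC2)C(=O)N1CCCCN1CCN(c2ncccc2Cl)CC1` keeps the core of compound 2 and alters only the pyridine substituent: chloro in place of nitro on an aromatic carbon. Among the compounds with values here, no measured pair tests nitro against chloro. Within the data shown here, the only step at this place, no change at the digits printed from compound 1 to compound 3 (within the scatter), concerns phenyl against chloro and was flat, so chloro at this position has not so far moved the number in this assay. As far as these compounds go, with compound 3 carrying chloro at 16 nM and compound 2 at 34.1 nM, a modest fall is expected for compound 4, a 1.7-fold lower number from compound 2 to compound 4 (0.23 log units; within the scatter), though the two cores differ and that part remains untested. Compound 4 is therefore estimated at 20 nM, with a range from 8 nM to 50 nM.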

Compound 4, half-maximal inhibitory concentration: 19.9 nM
Estimate against measurement, compound 4: 1.0-fold (0.00 log units) above; low and high end bracket the measured number.
By their numbers in this assay, from the lowest: compounds 1, 3, 4 and 2 (each within the scatter of the next, the first and the last beyond it).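

With the core of compound 2 held fixed, the exchange of nitro for chloro gives a 1.7-fold lower number from compound 2 to compound 4 (0.23 log units; within the scatter) in this assay, so this first direct test of the two groups does not separate them. Read beside the earlier exchange of phenyl for chloro in the other core, no change at the digits printed from compound 1 to compound 3 (within the scatter), it means that neither exchange on this aromatic carbon has moved the number beyond the scatter, although the groups leaving differ and nitro brings hydrogen-bond acceptors that chloro lacks. Nothing in the available data explains why these exchanges leave the number within the scatter.

The compounds shown leave open whether this tolerance extends to an amine or a methoxy group on the same carbon, since only phenyl, nitro and chloro appear there, and each exchange was read in one core only. They also leave open whether any substituent at this place behaves alike in both cores: with chloro in each, compound 3 gives 16 nM and compound 4 gives 19.9 nM, and that single pair is all that bears on the core.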